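A few compounds are considered here, and "the series" means these few. Any claim that something is new, unique, unknown or untested is made for them only; others in the source may bear on it.

Measured so far in a toxicity assay on HepG2 2.2.15 cells (Homo sapiens) for cytotoxicity, read by CellTiter-Glo; a higher number here means that more compound is tolerated, a lower number that less compound is tolerated:

- Compound 1 `O=C1CC(Oc2ncccn2)CN1c1cnn2c1CN(C(=O)Nc1cc(F)c(F)c(F)c1)C(C1CC1)C2`: > 200000 nM
- Compound 2 `O=C(Nc1cc(F)c(F)c(F)c1)N1CCCn2ncc(N3CC(c4ccccc4)CC3=O)c2C1`: > 2000 nM

Compound 2 has no exact number in this assay. Its reading of > 2000 nM is a limit of the assay. Compound 1 also has only a limit, > 200000 nM. For the measured compounds named here, with no exact value for either compound, the pair gives no measured step, and the two limits cannot be used to rank the compounds.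

Compound 3 `CC1CCn2ncc(N3CC(c4ccccc4)CC3=O)c2CN1C(=O)Nc1cc(F)c(F)c(F)c1` is built from compound 2 by one small edit: methyl in place of hydrogen on a saturated ring carbon. This places methyl in place of hydrogen on a saturated ring carbon of the seven-membered non-aromatic ring.

Going by the values given here, no measured pair shows what this edit does in this assay, so any forecast is uncertain. The starting point is the limit of compound 2 at > 2000 nM, and a modest move toward more compound being tolerated is expected. The estimated change is a step that the limit leaves unreadable from compound 2 to compound 3. Another limit rather than an exact number is the likely report. Compound 3 is estimated at 5000 nM, with an expected range from 2000 nM to 30000 nM.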

Compound 3, half-maximal cytotoxic concentration: > 2000 nM
Compound 3 was reported as a limit; the forecaster's own chance of this, stated with the estimate: 75%; the middle value is on the limit's open side.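

Compound 2 and compound 3 both have only a limit in this assay, so no step can be read between them for methyl in place of hydrogen on a saturated ring carbon. The compounds shown leave open how much of either compound is tolerated in exact terms, and whether this methyl changes that amount.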